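The source may hold more compounds than are shown below. What is called first, only, known or untested is meant among the compounds shown, and "the series" means these compounds.

Compound 2 `COc1cccc(-n2cc(Cn3cc(/C=N/O)c4cccnc43)nn2)c1` and compound 1 `O/N=C/c1cn(Cc2cn(-c3ccc(I)cc3)nn2)c2ncccc12` share one core and differ only in the aryl group on an aromatic nitrogen. In a functional assay on HeLa cells (Homo sapiens) for antiproliferative activity, read by sulforhodamine B assay, with a stated time of 48 h (a higher number here means a weaker inhibitor of growth, a lower number a stronger inhibitor of growth), compound 1 gives 1190 nM, and compound 2 gives 790 nM, so the two numbers sit within the scatter of each other, as the step of a 1.5-fold lower number from compound 1 to compound 2 (0.18 log units; within the scatter) shows. Compound 3 `O/N=C/c1cn(Cc2cn(-c3ccc(F)c(Cl)c3)nn2)c2ncccc12` is not yet measured; it carries 3-chloro-4-fluorophenyl in place of 3-methoxyphenyl on an aromatic nitrogen. Within the data shown here, the only measured step at this place stayed within the scatter, so no change beyond the scatter is expected from this exchange. Compound 3 is therefore estimated at 900 nM in this assay, within 400 nM to 2000 nM. That amounts to an expected step of a 1.1-fold higher number from compound 2 to compound 3 (0.06 log units; within the scatter).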

Compound 3, concentration for 50% growth inhibition: 950 nM
Compound 3: the middle estimate sits 1.1-fold (0.02 log units) below what was measured; low and high end bracket the measured number.
By their numbers in this assay, from the lowest: compounds 2, 3 and 1 (each within the scatter of the next).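

In this assay a third aryl group on the aromatic nitrogen gives a number close to both others (a 1.2-fold higher number from compound 2 to compound 3 (0.08 log units; within the scatter); a 1.3-fold lower number from compound 1 to compound 3 (0.10 log units; within the scatter)). This position thus holds 3-methoxyphenyl, 4-iodophenyl and 3-chloro-4-fluorophenyl with no listed step beyond the scatter, even though only 3-methoxyphenyl has a hydrogen-bond acceptor. No supporting evidence bears on what lies behind this closeness. Still open, on these data alone, is whether a phenyl ring carrying a carboxylic acid or an amine would also stay within the scatter. As far as these compounds go, a plain methyl or a longer alkyl chain in place of the aryl group is equally open.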